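The compounds below may be only part of what the source reports. "The series", "measured", "known", "first", "only" and "open" are said of these compounds alone.

Notes on the series. Three compounds of the shared core have been run in an ADME assay on PC-3 cells (Homo sapiens) for cytotoxicity, read by WST assay, tested at 100 uM; a lower number here means less inhibition, a higher number more inhibition at the concentration tested (going by the name of the read-out). Compound 1 `O=C(Nc1cccc(-c2cnco2)c1)C1CCCN(C(=O)c2cc(C(F)(F)F)cc(C(F)(F)F)c2)C1` gives 9% in this assay, and compound 2 `O=C(Nc1ccc(Cl)cc1)C1CCCN(C(=O)c2ccc(-c3ccco3)cc2)C1` gives 6%. Compound 3 `O=C(Nc1ccc(Cl)cc1)C1CCCN(C(=O)c2cccc(-c3nccs3)c2)C1` gives 32%, the highest of the three numbers, standing beyond the scatter above compound 1 and further still above compound 2. The next compound, compound 4 `O=C(Nc1ccc(Cl)cc1)C1CCCN(C(=O)c2cccc(-c3cnco3)c2)C1`, differs from compound 3 in one place: 1,3-oxazol-5-yl in place of 1,3-thiazol-2-yl on an aromatic carbon. Going by the values given here, no measured pair in the set shows this exact change on this core, so the size of the step is open. Since compound 1, which carries the 1,3-oxazol-5-yl group, gives 9%, a drop from compound 3 is expected, of the size a number 17 percentage points lower from compound 3 to compound 4 (beyond the scatter). Compound 4 is therefore estimated at 15%, within 3% to 30%.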

Compound 4, a percentage reported as inhibition, at one concentration (the size of the read-out at that concentration, not a potency): 0%
Compound 4: middle estimate off by 15 percentage points, on the high side; the whole stated range lies above it.
By their numbers in this assay, from the lowest: compounds 4, 2 and 1 (each within the scatter of the next); then compound 3.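

In this assay, going by these compounds alone, the change from 1,3-thiazol-2-yl to 1,3-oxazol-5-yl, on an aromatic carbon meta to a large group, gives a number 32 percentage points lower from compound 3 to compound 4 (beyond the scatter) as the first one-place pair. The step is large even though the two groups have the same counts of heavy atoms, hydrogen-bond donors and hydrogen-bond acceptors, so those counts alone do not set the reading here. Nothing available bears on the reason for the step. Open, going by these compounds, is how other groups at this position would read, such as an amine, a carboxylic acid or a plain phenyl ring. Also open, on these data alone, is whether the same change gives a step of this size on another core.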